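Hydroxyphenyl Hydrazone Variants: Estimating Compound 4

This account rests on a few compounds, and the source may have more. Where it says the series, first, only, none or still open, it means among the compounds named here.

Compound 1 `Cc1c(C(=O)N/N=C\c2ccccc2C(F)(F)F)oc2cccc(O)c12`: 26200 nM
Compound 2 `Cc1c(C(=O)N/N=C\c2c(O)cccc2F)oc2cccc(O)c12`: 8050 nM
Compound 3 `Cc1ccc(O)c(/C=N\NC(=O)c2oc3cccc(O)c3c2C)c1`: 7350 nM

In a functional assay on PC-3 cells (Homo sapiens) for inhibition (on this read-out lower numbers stand for stronger inhibition and higher numbers for weaker inhibition), compound 2 gives 8050 nM, the second highest of the three numbers. Compound 3 lies close by, since the step of a 1.1-fold lower number from compound 2 to compound 3 (0.04 log units; within the scatter) stays within the scatter, while compound 1 gives a clearly higher number, so compound 2 sits between them. Compound 4 `Cc1c(C(=O)N/N=C\c2cccc(O)c2)oc2cccc(O)c12` has not been measured yet; it differs from compound 2 by 3-hydroxyphenyl in place of 2-fluoro-6-hydroxyphenyl on a carbon with a double bond to nitrogen. Among the compounds with values here, the only measured step that bears on exchanging this ring is a 1.1-fold lower number from compound 2 to compound 3 (0.04 log units; within the scatter), where another hydroxyl-bearing ring replaced the same group without a shift beyond the scatter. A similarly small step is therefore expected: a 1.1-fold higher number from compound 2 to compound 4 (0.05 log units; within the scatter). Compound 4 is estimated at 9000 nM, in the range 3500 nM to 25000 nM.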

Compound 4, half-maximal inhibitory concentration: 17600 nM
For compound 4 the middle estimate is 2.0-fold (0.29 log units) below the measured one; low and high end bracket the measured number.
By their numbers in this assay, from the lowest: compounds 3 and 2 (each within the scatter of the next); then compounds 4 and 1 (each within the scatter of the next).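

Carrying a hydroxyl on this ring is not enough to keep the number unchanged in this assay: 3-hydroxyphenyl gives a 2.2-fold higher number from compound 2 to compound 4 (0.34 log units; beyond the scatter) and a 2.4-fold higher number from compound 3 to compound 4 (0.38 log units; beyond the scatter), both modest but beyond the scatter. The earlier exchange of one hydroxyl-bearing ring for another, a 1.1-fold lower number from compound 2 to compound 3 (0.04 log units; within the scatter), stayed within the scatter, so this place on the molecule does respond to the choice of ring. Nothing available explains the rise.

Still open, from the compounds shown here alone, is whether the hydroxyl's location or the loss of the fluorine or methyl drives the change. How an amine or a carboxylic acid on this ring would read is also unknown.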